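This account rests on a few compounds, and the source may have more. Where it says the series, first, only, none or still open, it means among the compounds named here.

Compound 1 `COc1ccc2c(=O)c(/C=C/C(=O)Nc3cc(C)ccc3C)coc2c1` and compound 2 `COc1ccc2c(=O)c(/C=C/C(=O)NCc3ccccc3F)coc2c1` share a core and differ only at the amide nitrogen. In a functional assay (QGY7701 cells, Homo sapiens) for inhibition, read by MTT assay, with a stated time of 48 h (on this read-out lower numbers stand for stronger inhibition and higher numbers for weaker inhibition), compound 1 reaches only the assay limit of > 100000 nM. In this assay, going by the values given here, compound 2 gives 34000 nM, the single number among the two results. Among the compounds with values here, the step of an at least 2.9-fold lower number from compound 1 to compound 2 (0.46 log units; beyond the scatter) is the only measured change. Compound 3 `COc1ccc2c(=O)c(/C=C/C(=O)Nc3ccc(F)cc3)coc2c1` carries the change (4-fluorophenyl in place of 2-fluorobenzyl on an amide-type nitrogen), returning the ring directly to the nitrogen as in compound 1, so a weaker result is expected, about a 2.1-fold higher number from compound 2 to compound 3 (0.31 log units; beyond the scatter). Compound 3 is estimated at 70000 nM, between 20000 nM and 200000 nM.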

Compound 3, half-maximal inhibitory concentration: > 100000 nM
Compound 3: no number, only a limit; the forecaster's own chance of this, stated with the estimate: 40%; at least 1.4-fold (0.15 log units) between middle value and limit.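

In this assay, the step to the ring set directly on the amide-type nitrogen is an at least 2.9-fold higher number from compound 2 to compound 3 (0.46 log units; beyond the scatter), and this time the fluorine is kept, so of the three compounds only the benzyl compound 2 gives a number. Compound 3 reaches only a limit, > 100000 nM. The step between compound 1 and compound 3 cannot be read, because both values are limits: the limit of > 100000 nM in this assay, at which 2 of the 3 values shown sit.

On these data alone, whether a benzyl without fluorine or a longer chain such as phenethyl would give a lower number stays open. The separate contributions of the extra carbon and of the fluorine's placement also remain unresolved.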